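This account rests on a few compounds, and the source may have more. Where it says the series, first, only, none or still open, it means among the compounds named here.

Working notes on the series, read in a functional assay on A549 cells (Homo sapiens) for antiproliferative activity, read by MTT assay, with a stated time of 72 h; on this read-out lower numbers stand for stronger inhibition and higher numbers for weaker inhibition. For the measured compounds named here, compound 3 `NC1=NC2(CCOCC2)N(OCCCOc2ccc(F)cc2)C(N)=N1` gives 1060 nM, the highest number so far, against compound 1 `NC1=NC2(CCOCC2)N(OCCCOc2ccc(Cl)cc2)C(N)=N1` at 360 nM and compound 2 `NC1=NC2(CCOCC2)N(OCCCOc2cccc(Cl)c2Cl)C(N)=N1` at 100 nM. Compound 4 `NC1=NC2(CCOCC2)N(OCCCOc2ccc(Cl)c(Cl)c2)C(N)=N1` differs from compound 3 as follows: 3,4-dichlorophenyl in place of 4-fluorophenyl on an oxygen on a saturated carbon. That is 3,4-dichlorophenyl in place of 4-fluorophenyl on an oxygen on a saturated carbon. Going by the values given here, two measured steps bear most directly on it, the modest 2.9-fold higher number from compound 1 to compound 3 (0.47 log units; beyond the scatter) and the large 11-fold higher number from compound 2 to compound 3 (1.03 log units; beyond the scatter). Also relevant is the modest 3.6-fold lower number from compound 1 to compound 2 (0.56 log units; beyond the scatter). Among the compounds with values here, no measured compound carries the 3,4-dichlorophenyl group, so a lower number of modest to large size is expected. The estimated step is a 6.2-fold lower number from compound 3 to compound 4 (0.79 log units; beyond the scatter). For compound 4 the estimated value is 170 nM, with an expected range of 60 nM to 450 nM.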

Compound 4, half-maximal inhibitory concentration: 790 nM
Beside the measured number, compound 4's estimate is 4.6-fold (0.67 log units) below it; the whole stated range lies below it.
By their numbers in this assay, from the lowest: compound 2; then compound 1; then compounds 4 and 3 (each within the scatter of the next).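

Across the dichlorophenyl pair, where the two chloro groups sit decides the outcome in this assay: 3,4-dichlorophenyl in place of 2,3-dichlorophenyl gives a 7.9-fold higher number from compound 2 to compound 4 (0.90 log units; beyond the scatter) and so does not keep the low number of compound 2. Chloro in place of hydrogen on an aromatic carbon gives a 2.2-fold higher number from compound 1 to compound 4 (0.34 log units; beyond the scatter), so adding a chloro does not by itself lower the number here. Set against the 4-fluorophenyl group, 3,4-dichlorophenyl gives a 1.3-fold lower number from compound 3 to compound 4 (0.13 log units; within the scatter) and no separation. As far as these compounds go, whether a 2-chlorophenyl, a 3-chlorophenyl or a longer chain would follow compound 2 or compound 4 stays open. No evidence is available on what underlies the gap between the two dichlorophenyl groups.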